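From ethylamino to dimethylamino: same atoms, rearranged

The source may report more compounds than this note shows. Statements on the series, on what has been measured and on what is new or still open speak of the compounds shown alone.

Values in a functional assay on HCT-8 cells (Homo sapiens) for antiproliferative activity, read by MTT assay, with a stated time of 48 h; on this read-out higher numbers stand for weaker inhibition and lower numbers for stronger inhibition:
- Compound 1 `C=C(c1ccc2c(c1)C=CC(C)(C)O2)c1ccc(OC)cc1NC(=O)CO`: 220 nM
- Compound 2 `C=C(c1ccc2c(c1)C=CC(C)(C)O2)c1ccc(OC)cc1NC(=O)CNC`: 590 nM
- Compound 3 `C=C(c1ccc2c(c1)C=CC(C)(C)O2)c1ccc(OC)cc1NC(=O)CNCC`: 2220 nM
- Compound 4 `C=C(c1ccc2c(c1)C=CC(C)(C)O2)c1ccc(OC)cc1NC(=O)CN(C)C`: not yet measured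

Compound 3 gives 2220 nM, the highest number of the three and so the weakest inhibition, with its steps to both others beyond the scatter. Compound 4 rearranges the same atoms: dimethylamino in place of ethylamino on a saturated chain carbon bound to a carbonyl carbon. The closest guide is a 3.8-fold higher number from compound 2 to compound 3 (0.58 log units; beyond the scatter), where methyl replaces hydrogen on a saturated chain carbon bound to an amine nitrogen. Another is a 2.7-fold higher number from compound 1 to compound 2 (0.43 log units; beyond the scatter). Going by the values given here, no measured pair makes this exact swap, so these steps suggest only a rough size. In this assay, the expected change is a 1.9-fold lower number from compound 3 to compound 4 (0.27 log units; within the scatter), so no shift beyond the scatter is firmly expected. For compound 4 the estimate is 1200 nM, with an expected range of 400 nM to 3500 nM.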

Compound 4, half-maximal inhibitory concentration: 690 nM
Compound 4: middle estimate off by 1.7-fold (0.24 log units), on the high side; the range from low to high includes it.
By their numbers in this assay, from the lowest: compound 1; then compounds 2 and 4 (each within the scatter of the next); then compound 3.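

Rearranging the same atoms still moves the number (a 3.2-fold lower number from compound 3 to compound 4 (0.51 log units; beyond the scatter)), so on this saturated chain carbon bound to a carbonyl carbon, how the atoms are joined matters, not only which atoms are present. Methyl in place of hydrogen on the amine nitrogen removes the hydrogen-bond donor, yet the step stays within the scatter (a 1.2-fold higher number from compound 2 to compound 4 (0.07 log units; within the scatter)). Hydroxy still gives the lower number (a 3.1-fold higher number from compound 1 to compound 4 (0.50 log units; beyond the scatter)). Nothing measured here explains these differences. On these data alone, whether a primary amine or a morpholine ring in this place would match hydroxy remains open.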